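The source may report more compounds than this note shows. Statements on the series, on what has been measured and on what is new or still open speak of the compounds shown alone.

The measured compounds are two:

Compound 1 `Cc1cc(O)cc(Oc2cc(C)c(Cc3ccc([C@](C)(O)CCCC(C)C)c(O)c3)c(O)c2)c1` gives 5400 nM in a functional assay on A549 cells (Homo sapiens) for cytotoxicity, read by sulforhodamine B assay, with a stated time of 72 h; a higher number here means a weaker inhibitor, a lower number a stronger inhibitor.
Compound 2 `C=C(C)CCC[C@](C)(O)c1ccc(C(=O)O)cc1O` gives "not active" (no number reported) in this assay.

For the measured compounds named here, compound 1 is the only one with a number in this assay. Going by the values given here, compound 2 has no single number there: it is recorded as showing no activity, so its standing on the scale cannot be fixed, and no step between compound 1 and compound 2 can be sized. The piece now turns to compound 3 `CC(=O)OC[C@@H](C)CCC[C@](C)(O)c1ccc(C(=O)O)cc1O`, which differs from compound 2 in one place: 1-(acetoxymethyl)ethyl in place of 1-methylethenyl on a saturated chain carbon, four bonds along the chain from an aromatic carbon and an oxygen on a saturated carbon. Among the compounds with values here, no measured pair shows what this kind of change does to the read-out, so nothing in the data fixes a direction or a size for the step from compound 2 to compound 3. Within the data shown here, the only anchor is that compound 2, the starting point, showed no activity at all, while compound 1, a much larger molecule, reached a number. Compound 3 is therefore expected to stay weak, with a real chance that it too is reported without a number. Compound 3 is estimated at 60000 nM, in a range from 15000 nM to 200000 nM.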

Compound 3, half-maximal inhibitory concentration: "not active" (no number reported)
The entry for compound 3 holds no number; the estimate stays without a comparison.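

In this assay compound 3, like compound 2, is recorded as showing no activity, without a number, so no step can be read between compound 2 and compound 3. On these data alone, what swapping 1-methylethenyl for 1-(acetoxymethyl)ethyl does to the read-out stays open. No measurement shown here bears on this result.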